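Dichloro to methoxy to difluoro on the carbonyl-bound ring

The source may report more compounds than this note shows. Statements on the series, on what has been measured and on what is new or still open speak of the compounds shown alone.

Compound 1 `COc1cc(-c2cc(/C=C/C(=O)c3ccc(Cl)c(Cl)c3)[nH]n2)cc(OC)c1OC` and compound 2 `COc1ccc(C(=O)/C=C/c2cc(-c3cc(OC)c(OC)c(OC)c3)n[nH]2)cc1` share a core and differ only on the carbonyl carbon. In a functional assay on OVCAR-4 cells (Homo sapiens) for cytotoxicity, read by sulforhodamine B assay, with a stated time of 48 h, tested at 0.01 uM (a lower number here means a stronger effect, a higher number a weaker effect of the compound at the concentration tested), compound 1 gives 92%, and in this assay compound 2 gives 91%. The step of a number 1 percentage points lower from compound 1 to compound 2 (within the scatter) puts compound 2 alongside compound 1, with no separation beyond the scatter between the two numbers shown.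

Compound 3 `COc1cc(-c2cc(/C=C/C(=O)c3ccc(F)c(F)c3)[nH]n2)cc(OC)c1OC` is not yet measured. It differs from compound 2 by 3,4-difluorophenyl in place of 4-methoxyphenyl on a carbonyl carbon. Among the compounds with values here, the one measured step that bears on this change is the one from compound 1 to compound 2, which swapped the ring on the same carbonyl carbon and moved the read-out by a number 1 percentage points lower from compound 1 to compound 2 (within the scatter), within the scatter. On that basis, no step beyond the scatter is expected for compound 3; the expected step is no change at the digits printed from compound 2 to compound 3 (within the scatter). Compound 3 is therefore estimated at 91%, with a range from 80% to 100%.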

Compound 3, a percentage reported as activity, at one concentration (the size of the read-out at that concentration, not a potency): 90%
Estimate against measurement, compound 3: 1 percentage points above; low and high end bracket the measured number.
By their numbers in this assay, from the lowest: compounds 3, 2 and 1 (each within the scatter of the next).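

With 3,4-difluorophenyl on the carbonyl carbon, this assay shows a number 1 percentage points lower from compound 2 to compound 3 (within the scatter) and a number 2 percentage points lower from compound 1 to compound 3 (within the scatter) for the two other rings tested there. This position has now carried three different aryl groups without any pair of compounds separating beyond the scatter, and this includes the swap that removes the one hydrogen-bond acceptor counted on the 4-methoxyphenyl group, with no separation between compound 2 and compound 3 at the single concentration tested.

Still open, as far as these compounds go, is whether an amine, a carboxylic acid or a longer chain on this carbonyl carbon would move the read-out beyond the scatter, and whether these three compounds would separate at another concentration. No supporting measurement is available to explain why the three rings give such similar read-outs.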